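Chain-extended dimethylbenzyl analog in the sigma-1 series

A few compounds are considered here, and "the series" means these few. Any claim that something is new, unique, unknown or untested is made for them only; others in the source may bear on it.

In an assay on liver for displacement of a labelled ligand from Sigma non-opioid intracellular receptor 1 (Rattus norvegicus) (on this read-out lower numbers stand for stronger inhibition and higher numbers for weaker inhibition), compound 2 `CN(CCCCc1cn(-c2ccc(F)cc2)c2ccccc12)Cc1ccccc1` gives 43 nM, the lowest number of the three measured compounds. Compound 1 `CN(CCCCc1cn(-c2ccc(F)cc2)c2ccccc12)Cc1cccc(Cl)c1` gives 201 nM, and compound 3 `Cc1ccc(CN(C)CCCc2cn(-c3ccc(F)cc3)c3ccccc23)cc1C` gives 118 nM. Among the compounds with values here, the only single-point step among the measured compounds is a 4.7-fold lower number from compound 1 to compound 2 (0.67 log units; beyond the scatter), so a substituent added to the benzyl ring has, in that one case, raised the number. Compound 4 `Cc1ccc(CN(C)CCCCc2cn(-c3ccc(F)cc3)c3ccccc23)cc1C` has not yet been measured. It differs from compound 2 by 3,4-dimethylphenyl in place of phenyl on a saturated chain carbon bound to an amine nitrogen. Within the data shown here, no measured pair isolates this exact change; compound 3 carries the same 3,4-dimethylbenzyl group on a shorter chain and sits above compound 2, which points the same way as the chloro step, though compound 3 also differs in the chain and so does not settle the size. The expectation for compound 4 in this assay is therefore a modest rise in the number, a 2.3-fold higher number from compound 2 to compound 4 (0.37 log units; beyond the scatter), beyond the scatter but smaller than a large shift. Compound 4 is estimated at 100 nM, with a range from 40 nM to 250 nM.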

Compound 4, inhibition constant: 20.8 nM
Compound 4: the middle estimate sits 4.8-fold (0.68 log units) above what was measured; the measured number lies below the stated range.
By their numbers in this assay, from the lowest: compound 4; then compound 2; then compounds 3 and 1 (each within the scatter of the next).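

On the benzyl end of the four-carbon chain, a substituted ring does not always raise the number in this assay: 3,4-dimethylphenyl in place of phenyl on a saturated chain carbon bound to an amine nitrogen gives (a 2.1-fold lower number from compound 2 to compound 4 (0.32 log units; beyond the scatter)), against the direction of the chloro step (a 4.7-fold lower number from compound 1 to compound 2 (0.67 log units; beyond the scatter)). At the same place, 3,4-dimethylphenyl in place of 3-chlorophenyl gives a wider gap (a 9.7-fold lower number from compound 1 to compound 4 (0.99 log units; beyond the scatter)), so within these three compounds the outcome depends on which substituents enter, not on substitution as such. (Nothing available here accounts for the difference between the chloro and dimethyl groups)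

The compounds shown leave open whether a single methyl, as in 3-methylbenzyl or 4-methylbenzyl, carries the step. They also leave open whether 3,4-dichlorobenzyl or 3,4-dimethoxybenzyl would fall with compound 4 or with compound 1.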